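Swapping the furan for a methoxyphenoxy group at the pendant aryl

The compounds below may be only part of what the source reports. "The series", "measured", "known", "first", "only" and "open" are said of these compounds alone.

Compound 1, `Cc1ccccc1-n1nc(C)c2c1NC(=O)[C@H](C)S[C@@H]2c1ccc(-c2cc3ccccc3o2)cc1`: 1500 nM
Compound 2, `Cc1ccccc1-n1nc(C)c2c1NC(=O)[C@H](C)S[C@@H]2c1ccc(-c2ccco2)cc1`: 3600 nM

In an assay on isolated protein for agonist activity at Bile acid receptor (Homo sapiens), read by AlphaScreen, with a stated time of 30 min (on this read-out lower numbers stand for an effect already at smaller amounts and higher numbers for an effect only at larger amounts of compound), compound 2 stands highest of the two numbers measured, with 3600 nM. Its nearest neighbour is compound 1 with 1500 nM. Among the measured compounds shown here, the one step measured so far, a 2.4-fold higher number from compound 1 to compound 2 (0.38 log units; beyond the scatter), shows that the smaller furan-2-yl group weakens the effect relative to the benzofuran. Compound 3, `COc1ccccc1Oc1ccc([C@H]2S[C@@H](C)C(=O)Nc3c2c(C)nn3-c2ccccc2C)cc1`, carries the change (2-methoxyphenoxy in place of furan-2-yl on an aromatic carbon). Because the reverse direction of a 2.4-fold higher number from compound 1 to compound 2 (0.38 log units; beyond the scatter) favoured the larger group, the entering group of compound 3 is expected to bring a lower number, roughly a 1.8-fold lower number from compound 2 to compound 3 (0.26 log units; within the scatter). Compound 3 is thus estimated at 2000 nM, with a range from 600 nM to 7000 nM.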

Compound 3, half-maximal effective concentration: 1700 nM
Compound 3: middle estimate off by 1.2-fold (0.07 log units), on the high side, within the range that was stated.
By their numbers in this assay, from the lowest: compounds 1 and 3 (each within the scatter of the next); then compound 2.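

In this assay, 2-methoxyphenoxy at this position, para to a large group, gives a 2.1-fold lower number from compound 2 to compound 3 (0.33 log units; beyond the scatter), so a lower number than that of furan-2-yl is not confined to 1-benzofuran-2-yl. The comparison with the benzofuran shows a 1.1-fold higher number from compound 1 to compound 3 (0.05 log units; within the scatter), which leaves 2-methoxyphenoxy and 1-benzofuran-2-yl unseparated on this read-out. Nothing available explains this result. From the compounds shown here alone, it remains open whether the methoxy group of compound 3 matters compared with an unsubstituted phenoxy group, and how an amine or a carboxylic acid would fare at this position.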